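Replacing the 3-chlorophenyl group of compound 2

The source may hold more compounds than are shown below. What is called first, only, known or untested is meant among the compounds shown, and "the series" means these compounds.

Of the compounds shown here, two sharing one core have been measured in a functional assay on RAW264.7 cells (Mus musculus), read by fluorescence; on this read-out lower numbers stand for stronger inhibition and higher numbers for weaker inhibition. Compound 1 (`CCOC(=O)C1=CCCCC1S(=O)(=O)Cc1ccccc1F`) gives 97 nM, and compound 2 (`CCOC(=O)C1=CCCCC1S(=O)(=O)Cc1cccc(Cl)c1`) gives 14 nM, the lower of the two numbers. Going by the values given here, the one measured step, a 6.9-fold lower number from compound 1 to compound 2 (0.84 log units; beyond the scatter), is beyond the scatter and came from exchanging 2-fluorophenyl for 3-chlorophenyl. Compound 3 (`CCOC(=O)C1=CCCCC1S(=O)(=O)Cc1ccsc1`) alters the same place, a saturated chain carbon bound to a sulfonyl sulfur: thiophen-3-yl in place of 3-chlorophenyl on a saturated chain carbon bound to a sulfonyl sulfur. That step, a 6.9-fold lower number from compound 1 to compound 2 (0.84 log units; beyond the scatter), shows that this place can move the number, but it involves no thiophen-3-yl, so it offers only a rough guide to size. With compound 2 at the low end at 14 nM, a move towards weaker inhibition seems likelier, though somewhat smaller than that step. The expected change is a 3.2-fold higher number from compound 2 to compound 3 (0.51 log units; beyond the scatter). Compound 3 is estimated at 45 nM, with an expected range from 15 nM to 140 nM.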

Compound 3, half-maximal inhibitory concentration: 105 nM
For compound 3 the middle estimate is 2.3-fold (0.37 log units) below the measured one, within the range that was stated.
By their numbers in this assay, from the lowest: compound 2; then compounds 1 and 3 (each within the scatter of the next).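

In this assay, the place on a saturated chain carbon bound to a sulfonyl sulfur now shows a second step beyond the scatter (a 7.5-fold higher number from compound 2 to compound 3 (0.88 log units; beyond the scatter)), so the low number of compound 2 does not carry over when thiophen-3-yl enters. Compound 1 and compound 3, with 2-fluorophenyl and thiophen-3-yl, lie within the scatter of each other (a 1.1-fold higher number from compound 1 to compound 3 (0.03 log units; within the scatter)), which leaves compound 2, with 3-chlorophenyl, alone at the low end of these three. No measurement presented here accounts for this separation.

As far as these compounds go, it remains open whether a plain phenyl or a 3-bromophenyl group at this place would give a number near that of compound 2 or near those of compound 1 and compound 3. From the compounds shown here alone, how an amine on the aromatic ring would change the number also remains open.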